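The source may hold more compounds than are shown below. What is called first, only, known or untested is meant among the compounds shown, and "the series" means these compounds.

Working notes on the series. Compound 1 `CN1CCN(c2nc(N)nc(Cc3ccc(Cl)cc3)n2)CC1` carries the 4-chlorophenyl group on the shared core, and in an assay on HEK293 cells for displacement of a labelled ligand from 5-hydroxytryptamine receptor 6 (Homo sapiens) (a lower number here means a stronger inhibitor, a higher number a weaker inhibitor), compound 1 gives 52 nM. Compound 2 `CN1CCN(c2nc(N)nc(Cc3ccccc3F)n2)CC1` gives 88 nM in this assay, and compound 3 `CN1CCN(c2nc(N)nc(Cc3cccc(F)c3)n2)CC1` gives 64 nM. On these three numbers compound 3 stands second highest; its nearest neighbour is compound 1 and its furthest is compound 2, and both gaps lie within the scatter. The measured steps of a 1.7-fold higher number from compound 1 to compound 2 (0.23 log units; within the scatter), a 1.2-fold higher number from compound 1 to compound 3 (0.09 log units; within the scatter) and a 1.4-fold lower number from compound 2 to compound 3 (0.14 log units; within the scatter) all stay within the scatter, so moving the halogen around the phenyl ring, or exchanging chlorine for fluorine, has not shifted this assay beyond its usual spread.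

Compound 4 `CN1CCN(c2nc(N)nc(Cc3cccs3)n2)CC1` is not yet measured. The change is thiophen-2-yl in place of 3-fluorophenyl on a saturated chain carbon bound to an aromatic carbon. Among the measured compounds shown here, none of the measured steps replaces the aromatic ring itself; they only show that variation on the phenyl ring leaves this assay flat. The ring exchange therefore lies outside what the three steps cover, and the expectation rests on that flatness alone: the expected step is a 1.1-fold higher number from compound 3 to compound 4 (0.04 log units; within the scatter), with a range widened to allow for the untested exchange. Compound 4 is expected to give 70 nM in this assay, between 30 nM and 170 nM.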

Compound 4, inhibition constant: 305 nM
The estimate for compound 4 lay 4.4-fold (0.64 log units) below the measured number, outside the stated range (above it).
By their numbers in this assay, from the lowest: compounds 1, 3 and 2 (each within the scatter of the next); then compound 4.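

In this assay the aromatic ring itself on the saturated chain carbon bound to an aromatic carbon proves to matter, which the phenyl variations could not show: the exchange for thiophen-2-yl gives a 4.8-fold higher number from compound 3 to compound 4 (0.68 log units; beyond the scatter) and a 3.5-fold higher number from compound 2 to compound 4 (0.54 log units; beyond the scatter) and also a 5.9-fold higher number from compound 1 to compound 4 (0.77 log units; beyond the scatter) in the same direction. Among these four compounds, then, the three halogen-bearing phenyl groups form one group within the scatter of each other, and the five-membered ring with its sulfur atom stands apart from all three, with no compound shown going against this. The measurements shown offer no account of why this exchange raises the number.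

The step changes several things at once, the ring size, the hetero atom and the presence of a halogen, and the compounds shown do not separate them. From the compounds shown here alone, it stays open whether an unsubstituted phenyl would stay with the halogen-bearing phenyl compounds or move toward compound 4, and whether thiophen-3-yl or furan-2-yl would behave as the thiophen-2-yl group does.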